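From Butyl to (Furan-2-yl)methyl on the Shared Core

A few compounds are considered here, and "the series" means these few. Any claim that something is new, unique, unknown or untested is made for them only; others in the source may bear on it.

Compound 1 `CCCC/N=C(\NC#N)Nc1cccnc1` stands highest of the two numbers measured in a functional assay on the whole organism (blood, strain Wistar-Okamoto) with Rattus norvegicus as the target, with a stated time of 5 days (on this read-out higher numbers stand for an effect only at larger amounts of compound and lower numbers for an effect already at smaller amounts), where compound 1 gives 20 mg/kg. Compound 2 `CCC(C)(CC)/N=C(\NC#N)Nc1cccnc1` gives 0.5 mg/kg in this assay, and the step of a 40-fold lower number from compound 1 to compound 2 (1.60 log units; beyond the scatter) is large. Compound 3 `N#CN/C(=N\Cc1ccco1)Nc1cccnc1` differs from compound 1 by furan-2-yl in place of propyl on a saturated chain carbon bound to a double-bonded nitrogen. Going by the values given here, only that one step bears on the present change, and it shows the number can move far at this position; the present change is of another kind, so its size cannot be read from it. Compound 3 is therefore expected to show a modest step, a 2.0-fold lower number from compound 1 to compound 3 (0.30 log units; within the scatter), toward a lower number. The value of compound 3 is estimated at 10 mg/kg, with a range from 2 mg/kg to 50 mg/kg.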

Compound 3, minimum effective dose: 20 mg/kg
Compound 3: the middle estimate sits 2.0-fold (0.30 log units) below what was measured; the range from low to high includes it.
By their numbers in this assay, from the lowest: compound 2; then compounds 1 and 3 (each within the scatter of the next).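

In this assay, butyl gives way to (furan-2-yl)methyl with no change at the digits printed from compound 1 to compound 3 (within the scatter), so a five-membered aromatic ring can enter on this double-bonded nitrogen and leave compound 3 within the scatter of compound 1. The low number of compound 2 does not carry over to this group, as a 40-fold higher number from compound 2 to compound 3 (1.60 log units; beyond the scatter) shows. Nothing measured here offers a reason for this result. Still open, on these data alone, is whether a longer chain such as hexyl, or a phenylmethyl group in place of (furan-2-yl)methyl, would stay with compounds 1 and 3 or approach compound 2.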